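A few compounds are considered here, and "the series" means these few. Any claim that something is new, unique, unknown or untested is made for them only; others in the source may bear on it.

Of the compounds shown here, three of one series have been tested in an ADME assay on L6 cells (Rattus norvegicus) for cytotoxicity, read by fluorescence, with a stated time of 72 h; a lower number here means a stronger inhibitor, a higher number a weaker inhibitor. Compound 1 `CN1CCN(C23CCN(CCCN4CCCCC4)C(C(c4ccccc4)C2)C(c2ccccc2)C3)CC1` gives 28900 nM; compound 3 `CN1CCN(C23CCN(CCCN4CCCC4)C(C(c4ccccc4)C2)C(c2ccccc2)C3)CC1` gives 43500 nM; compound 2 `CN1CCN(C23CC(NC(=O)CN4CCCCC4)C(C(c4ccccc4)C2)C(c2ccccc2)C3)CC1` gives 22100 nM, the lowest of the three numbers, though all three lie within the usual scatter of one another. Among the measured compounds shown here, the only single-point step among them, a 1.5-fold higher number from compound 1 to compound 3 (0.18 log units; within the scatter), exchanges one small saturated nitrogen ring for another and leaves the number essentially where it was.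

Compound 4 `CCN(CC)CCC(=O)NC1CC2(N3CCN(C)CC3)CC(c3ccccc3)C1C(c1ccccc1)C2` differs from compound 2 in one place: (diethylamino)methyl in place of piperidin-1-yl on a saturated chain carbon bound to a carbonyl carbon. Here the ring is opened rather than resized, and the change sits on the chain bound to the carbonyl carbon rather than on the chain three bonds from a ring amine nitrogen, so the measured step is only loosely comparable. Given that the step from compound 1 to compound 3 stayed within the scatter, no shift beyond the scatter is expected for this exchange either, so the estimated step is a 1.2-fold higher number from compound 2 to compound 4 (0.07 log units; within the scatter). Compound 4 is therefore expected to give about 26000 nM in this assay, with a plausible range from 11000 nM to 60000 nM.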

Compound 4, half-maximal inhibitory concentration: 35900 nM
Beside the measured number, compound 4's estimate is 1.4-fold (0.14 log units) below it, within the range that was stated.
By their numbers in this assay, from the lowest: compounds 2, 1, 4 and 3 (each within the scatter of the next).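

In this assay, replacing the ring at this place, on a saturated chain carbon bound to a carbonyl carbon, with an open chain gives a 1.6-fold higher number from compound 2 to compound 4 (0.21 log units; within the scatter). Among the compounds shown here, the earlier step exchanged only one ring for another on a different chain, whereas here piperidin-1-yl gives way to (diethylamino)methyl, which has no ring but the same heavy-atom count, and compound 2 and compound 4 remain within the scatter of each other. No supporting measurement bears on the reason for this result.

The compounds shown leave open whether a carboxylic acid or a morpholin-4-yl ring in place of the amine at this position would take the number beyond the scatter. They also leave open whether diethylamino would read the same on a saturated chain carbon, three bonds along the chain from an amine nitrogen in a ring.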